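The source may hold more compounds than are shown below. What is called first, only, known or untested is meant among the compounds shown, and "the series" means these compounds.

Compound 1 `CC(=O)Oc1ccc2c(c1)C(C)=CC(C)(C)N2Cc1ccccc1` gives 24000 nM in an ADME assay on L6 cells (Rattus norvegicus) for cytotoxicity, read by resazurin assay, with a stated time of 70 h; a lower number here means a stronger inhibitor, a higher number a weaker inhibitor. In this assay compound 2 `CC(=O)Oc1ccc2c(c1)C(C)=CC(C)(C)N2Cc1ccc(Cl)c(Cl)c1` gives 28000 nM and compound 3 `CC(=O)Oc1ccc2c(c1)C(C)=CC(C)(C)N2Cc1cccc(C)c1` gives 28000 nM. These three values lie within the scatter of one another, so compound 1 stands level with the other two and nothing separates them.

Compound 4 `CC1=CC(C)(C)N(Cc2ccccc2)c2ccc(OC(=O)C(C)(C)C)cc21` keeps the core of compound 1 and changes only the ester end, with tert-butyl in place of methyl on a carbonyl carbon. The measured steps are a 1.2-fold higher number from compound 1 to compound 2 (0.07 log units; within the scatter), a 1.2-fold higher number from compound 1 to compound 3 (0.07 log units; within the scatter) and no change at the digits printed from compound 2 to compound 3 (within the scatter). All three are small, but none touches this carbonyl carbon, so the series holds no direct measurement of the change, and these steps show only that this assay has stayed flat so far. No step beyond the scatter is therefore expected, though the range is kept wide. The expected step is a 1.2-fold higher number from compound 1 to compound 4 (0.07 log units; within the scatter). For compound 4 the estimated value is 28000 nM, with an expected range of 14000 nM to 55000 nM.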

Compound 4, half-maximal inhibitory concentration: 170000 nM
The estimate for compound 4 lay 6.1-fold (0.78 log units) below the measured number; the whole stated range lies below it.
By their numbers in this assay, from the lowest: compounds 1, 2 and 3 (each within the scatter of the next); then compound 4.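

Going by these compounds alone, the carbonyl carbon of the ester is the first place where this assay responds: tert-butyl in place of methyl gives a 7.1-fold higher number from compound 1 to compound 4 (0.85 log units; beyond the scatter), whereas the changes at the other end of the molecule in compound 2 and compound 3 stayed within the scatter of compound 1. Within the data shown here, the flatness of the earlier compounds therefore does not extend to the ester end, and the number here is sensitive to what sits on this carbonyl carbon. This rests on a single pair on the core of compound 1, and nothing available accounts for the step.

Ethyl or isopropyl on the same carbonyl carbon would show whether the number climbs gradually or only with tert-butyl. Also open, on these data alone, is whether the step persists on the 3,4-dichlorophenyl compound, or with an amide in place of the ester.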